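The source may hold more compounds than are shown below. What is called first, only, known or untested is meant among the compounds shown, and "the series" means these compounds.

Two glycosides carry numbers in a functional assay for inhibition, read by fluorescence, with a stated time of 5 min, in the presence of a further agent that is not named here; a lower number here means a stronger inhibitor, a higher number a weaker inhibitor. Compound 1 `C[C@]1(O)C[C@@H](OC(=O)c2ccc(O)cc2)[C@@H]2CCO[C@@H](O[C@@H]3O[C@H](CO)[C@@H](O)[C@H](O)[C@H]3O)[C@@H]21` gives 8300 nM. Compound 2 `O=C(C/C=C/c1ccc(O)cc1)OC[C@@]1(O)CO[C@@H](O[C@H]2[C@H](OCCc3ccc(O)cc3)O[C@H](CO)[C@@H](O)[C@@H]2O)[C@@H]1O` gives 4500 nM. Compound 2 holds the lower of the two numbers, but its gap to compound 1 is within the scatter, so the two are not separated by these data. Compound 3 `OC[C@H]1O[C@@H](OCCc2ccc(O)cc2)[C@H](O[C@@H]2OC[C@](O)(CO)[C@H]2O)[C@@H](O)[C@@H]1O` is not yet measured in this assay. It differs from compound 2 in one place: a hydrogen atom in place of a group of 12 heavy atoms (10 carbon, 2 oxygen; one six-membered aromatic ring of carbon only), on an oxygen on a saturated carbon. What leaves is a group of 12 heavy atoms (10 carbon, 2 oxygen) with one six-membered aromatic ring of carbon only and 2 double bonds outside aromatic rings; a hydrogen atom enters on an oxygen on a saturated carbon. Within the data shown here, no measured pair shows a step of this kind, so the direction rests on the size of the change alone. For compound 3 a weaker inhibitor is expected, with an estimated step of a 2.0-fold higher number from compound 2 to compound 3 (0.30 log units; within the scatter). Compound 3 is expected to give about 9000 nM, in a range from 3000 nM to 30000 nM.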

Compound 3, half-maximal inhibitory concentration: 15700 nM
Compound 3: the middle estimate sits 1.7-fold (0.24 log units) below what was measured; low and high end bracket the measured number.
By their numbers in this assay, from the lowest: compounds 2, 1 and 3 (each within the scatter of the next, the first and the last beyond it).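

In this assay, among these compounds, a hydrogen atom in place of the group of 12 heavy atoms on the oxygen on a saturated carbon gives a 3.5-fold higher number from compound 2 to compound 3 (0.54 log units; beyond the scatter), the first change that can be read at a single place and the first to show that this position affects the read-out. The step is modest, and compound 3 still gives 15700 nM, so a measurable number remains without the group and its six-membered aromatic ring. No supporting data explain the size of this step.

Which part of the group matters remains open: an acetyl group on the same oxygen would keep the attachment but lack the aromatic ring. Compound 1 differs from both compounds in more than one place and does not settle this.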